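A Fluorinated Naphthalene in Place of a Quinoline

The source may hold more compounds than are shown below. What is called first, only, known or untested is meant among the compounds shown, and "the series" means these compounds.

Measured compounds:
Compound 1, `O=C1C=CC2(C=C1)OCC(=O)N2c1nc(-c2ccc3ncccc3c2)nn1-c1ccccc1`: 110 nM
Compound 2, `Cc1ccccc1-n1nc(-c2cccc3ccccc23)nc1N1C(=O)COC12C=CC(=O)C=C2`: 100 nM

Both compounds were tested in a functional assay on HeLa cells (Homo sapiens) for antiproliferative activity, with a stated time of 5 days; a higher number here means a weaker inhibitor, a lower number a stronger inhibitor. Compound 1 gives 110 nM and compound 2 gives 100 nM. Compound 1 holds the larger of the two numbers, but its gap to compound 2 is within the usual scatter, so the two compounds cannot be told apart on these data.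

Compound 3, `O=C1C=CC2(C=C1)OCC(=O)N2c1nc(-c2ccc(F)c3ccccc23)nn1-c1ccccc1`, has not yet been measured. It differs from compound 1 in one place: 4-fluoronaphthalen-1-yl in place of quinolin-6-yl on an aromatic carbon. Among the compounds with values here, no step between two measured compounds is available to calibrate this change directly. What the data do offer is compound 2, which carries a naphthalen-1-yl group and returns a number indistinguishable from that of compound 1. On that basis the change from compound 1 to compound 3 is expected to give no step beyond the scatter in this assay, with the estimated step being a 1.3-fold lower number from compound 1 to compound 3 (0.11 log units; within the scatter). Compound 3 is therefore expected to give about 85 nM, with a likely range from 35 nM to 220 nM.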

Compound 3, half-maximal inhibitory concentration: 200 nM
Compound 3: the middle estimate sits 2.4-fold (0.37 log units) below what was measured; low and high end bracket the measured number.
By their numbers in this assay, from the lowest: compounds 2, 1 and 3 (each within the scatter of the next).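

In this assay, putting 4-fluoronaphthalen-1-yl in place of quinolin-6-yl on this aromatic carbon gives a 1.8-fold higher number from compound 1 to compound 3 (0.26 log units; within the scatter) and so stays within the usual scatter. Within the data shown here, this is the first direct reading at this position with only one place changed, and it shows that the ring nitrogen of quinolin-6-yl, with its hydrogen-bond acceptor, can leave while a fluorine enters, without a step these data can tell from scatter. No measurement shown here explains a step of this size.

The change replaces the whole group at once, so the share of the fluorine, that of the ring nitrogen and that of the different ring attachment cannot be read apart, and a plain naphthalen-1-yl on the core of compound 1 would be needed to begin separating them. It also remains open how far this position tolerates groups of a different kind, such as a carboxylic acid, a morpholine or a simple amine, since the groups shown here are all fused aromatic rings.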